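This account rests on a few compounds, and the source may have more. Where it says the series, first, only, none or still open, it means among the compounds named here.

Compound 1, `CCCCCOCCCCCCC/C=C1\CC(CO)(COC(=O)C(C)(C)C)OC1=O`, gives 1.15 ug/mL in a functional assay on K562 cells (Homo sapiens) for antiproliferative activity; on this read-out higher numbers stand for weaker inhibition of growth and lower numbers for stronger inhibition of growth.
Compound 2, `CC(=O)OCCCCCCCCCCCCCCC/C=C1\CC(CO)(COC(=O)C(C)(C)C)OC1=O`, gives 0.959 ug/mL in this assay.
Compound 3, `CC(C)(C)C(=O)OCCCCCCCCCCCCCCC/C=C1\CC(CO)(COC(=O)C(C)(C)C)OC1=O`, gives 0.352 ug/mL in this assay.

Compound 3 stands lowest of the three numbers; its nearest neighbour is compound 2, separated from it by a 2.7-fold lower number from compound 2 to compound 3 (0.44 log units; beyond the scatter), and compound 1 lies further off still. Compound 4, `COC(=O)CCCCCCCCCCCCCC/C=C1\CC(CO)(COC(=O)C(C)(C)C)OC1=O`, differs from compound 3 in one place: methoxycarbonyl in place of (((tert-butyl)carbonyl)oxy)methyl on a saturated chain carbon, ten or more bonds along the chain from a double-bonded chain carbon. Of the two measured steps, the one that bears most on this change is the swap of tert-butyl for methyl on a carbonyl carbon, which gave a 2.7-fold lower number from compound 2 to compound 3 (0.44 log units; beyond the scatter); compound 4 runs in the opposite sense, exchanging a tert-butyl ester for a methyl ester at the chain end, so a move back toward a higher number is expected. The step from pentyloxy to 8-acetoxyoctyl, a 1.2-fold lower number from compound 1 to compound 2 (0.08 log units; within the scatter), shows that changes at the far end of the chain can also pass within the scatter. The estimate for compound 4 in this assay is 0.8 ug/mL, between 0.3 ug/mL and 2 ug/mL. For compound 4 this expectation amounts to a 2.3-fold higher number from compound 3 to compound 4 (0.36 log units; beyond the scatter).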

Compound 4, concentration for 50% growth inhibition: 0.856 ug/mL
The estimate for compound 4 lay 1.1-fold (0.03 log units) below the measured number, and the stated range covers the measured number.
By their numbers in this assay, from the lowest: compound 3; then compounds 4, 2 and 1 (each within the scatter of the next).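

In this assay, methoxycarbonyl in place of (((tert-butyl)carbonyl)oxy)methyl gives a 2.4-fold higher number from compound 3 to compound 4 (0.39 log units; beyond the scatter). This shows that the separation of compound 3 holds against a second chain end as well as against acetoxymethyl. The methoxycarbonyl end does not separate from the other two, with a 1.1-fold lower number from compound 2 to compound 4 (0.05 log units; within the scatter) and a 1.3-fold lower number from compound 1 to compound 4 (0.13 log units; within the scatter), so among these four compounds only the chain end of compound 3 stands apart, while the ends of compounds 1, 2 and 4 cannot be told apart on this read-out.

No measurement at hand accounts for this separation. From the compounds shown here alone, it remains open whether a carboxylic acid or an amine at the chain end, or a longer chain ending in the same tert-butyl carbonyl group, would fall with compound 3 or with the other three.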